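Swapping Bromine for a Furan Ring on a Second Core

The source may report more compounds than this note shows. Statements on the series, on what has been measured and on what is new or still open speak of the compounds shown alone.

Compound 1, with the structure `CCCn1c(Br)nc2c(N)nc(NCc3ccccc3)nc21`, and compound 2, with the structure `CCCn1c(-c2ccco2)nc2c(N)nc(NCc3ccccc3)nc21`, share one core and differ in a single spot. In a functional assay on CHO cells for antagonist activity at adenosine receptor A2b (Homo sapiens) (on this read-out lower numbers stand for stronger inhibition and higher numbers for weaker inhibition), compound 1 gives 1740 nM, and compound 2 gives 4610 nM. The change from compound 1 to compound 2 is furan-2-yl in place of bromo on an aromatic carbon, and it gave a 2.6-fold higher number from compound 1 to compound 2 (0.42 log units; beyond the scatter), so the furan ring brought weaker inhibition than the bromine atom on this core.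

Compound 3, with the structure `CCCn1c(Br)nc2c(NCc3ccccc3)ncnc21`, is built on a different core; the difference between the two cores is not broken down here. In this assay compound 3 gives 7490 nM, the highest of the three measured numbers. Compound 4, with the structure `CCCn1c(-c2ccco2)nc2c(NCc3ccccc3)ncnc21`, has not yet been measured. Compound 4 differs from compound 3 by furan-2-yl in place of bromo on an aromatic carbon, which is the same change that separates compound 1 from compound 2.

If the second core responds the way the first did, compound 4 is expected to sit weaker than compound 3, with an estimated step of a 2.4-fold higher number from compound 3 to compound 4 (0.38 log units; beyond the scatter), because compound 2 followed compound 1 with a 2.6-fold higher number from compound 1 to compound 2 (0.42 log units; beyond the scatter). This rests on a single measured pair, and the two cores are not the same, so the expected range is kept wide. Compound 4 is estimated at 18000 nM, expected to fall between 6000 nM and 55000 nM in this assay.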

Compound 4, inhibition constant: 1760 nM
For compound 4 the middle estimate is 10-fold (1.01 log units) above the measured one; measured number below the stated range.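

On the second core, the furan-2-yl group in place of bromo brought stronger inhibition in this assay with a 4.3-fold lower number from compound 3 to compound 4 (0.63 log units; beyond the scatter) as the measured step, which runs opposite to the weaker inhibition the same swap brought on the first core. Set side by side, the two steps show that this swap did not carry over from one core to the other, in direction or in size: the same change on two cores in this assay, a 2.6-fold higher number (0.42 log units; beyond the scatter) from compound 1 to compound 2 and a 4.3-fold lower number (0.63 log units; beyond the scatter) from compound 3 to compound 4, 11-fold (1.05 log units) apart, beyond the scatter of two such steps. So a result for this change on one of these cores is a poor guide to its result on the other, but this rests on only two pairs of compounds, and it does not show why the cores differ, which part of them matters, or how the swap would behave on any further core.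

From the compounds shown here alone, it remains open whether other groups on the same aromatic carbon, such as a phenyl ring, a thiophene ring or a methyl group, would also move in opposite directions on the two cores. Going by these compounds, it is also open whether the split between the cores would survive if the propyl group gave way to a longer chain, such as a pentyl chain.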